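A few compounds are considered here, and "the series" means these few. Any claim that something is new, unique, unknown or untested is made for them only; others in the source may bear on it.

Measured so far in an assay on isolated protein for inhibition of long-chain fatty acid transport protein 1 (Mus musculus); a lower number here means a stronger inhibitor, a higher number a weaker inhibitor:
compound 1, `CCn1c(CNc2ccccc2)nnc1SCc1nc2cc(OC(F)(F)F)ccc2o1`: 91 nM
compound 2, `CCC(=O)c1ccc2nc(CSc3nnc(CNc4ccccc4)n3CC)oc2c1`: 1200 nM

Compound 1 gives the lowest number of the two in this assay; compound 2, in which a propanoyl group is carried on a core with a different orientation, gives the higher value, and the gap between the two lies beyond the scatter of repeated measurements. Going by the values given here, no step between measured compounds that differ in one place is available.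

Compound 3, `CCC(O)c1ccc2oc(CSc3nnc(CNc4ccccc4)n3CC)nc2c1`, is not yet measured. It differs from compound 1 in one place: 1-hydroxypropyl in place of trifluoromethoxy on an aromatic carbon. The trifluoromethoxy group of compound 1 is thus exchanged for a group of four heavy atoms that adds a hydrogen-bond donor.

With the high value of compound 2 as the only other point of reference, a moderate loss is expected for compound 3 in this assay, the step of a 4.4-fold higher number from compound 1 to compound 3 (0.64 log units; beyond the scatter) likely exceeding the scatter. The estimate for compound 3 is 400 nM, within 120 nM to 1500 nM.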

Compound 3, half-maximal inhibitory concentration: 3700 nM
Compound 3: middle estimate off by 9.3-fold (0.97 log units), on the low side; measured number above the stated range.
By their numbers in this assay, from the lowest: compound 1; then compound 2; then compound 3.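

In this assay, going by these compounds alone, the exchange of trifluoromethoxy for 1-hydroxypropyl on this aromatic carbon gives a 41-fold higher number from compound 1 to compound 3 (1.61 log units; beyond the scatter) and so supplies the only single-place step so far. The step shows that this position is sensitive to its substituent, since this one change, with the rest of the molecule held constant, moves the number well beyond the scatter. No measurement to hand explains the rise.

On these data alone, it remains open whether the step follows from the hydroxyl group or from the carbon chain of 1-hydroxypropyl, a distinction that a plain propyl group on the same carbon would address. Also open, as far as these compounds go, is how an amine or a carboxylic acid would read at this position.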